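The source may hold more compounds than are shown below. What is called first, only, known or untested is meant among the compounds shown, and "the series" means these compounds.

In a functional assay on MCF7 cells (Homo sapiens) for antiproliferative activity; a higher number here means a weaker inhibitor, a lower number a stronger inhibitor:
Compound 1 `Cc1nc2cc(Cl)c(Cl)cc2n1C1CCCC1`: 40000 nM
Compound 2 `C[S+]([O-])c1nc2cc(Cl)c(Cl)cc2n1C1CCCC1`: 500 nM

Of these two compounds, compound 2 has the lower number, 500 nM. Compound 3 `CS(=O)(=O)c1nc2cc(Cl)c(Cl)cc2n1C1CCCC1` has not yet been measured. It differs from compound 2 by one change: a group of 4 heavy atoms (1 carbon, 2 oxygen, 1 sulfur; no ring) in place of a group of 3 heavy atoms (1 carbon, 1 oxygen, 1 sulfur; no ring), on an aromatic carbon, with methylsulfonyl on an aromatic carbon. Within the data shown here, only one measured step bears on this change, an 80-fold lower number from compound 1 to compound 2 (1.90 log units; beyond the scatter). That large step replaced one carbon atom with a sulfur-containing group at the same aromatic carbon. Compound 3 keeps a sulfur-containing group there and gains one oxygen, so a much smaller step is expected in this assay, perhaps slightly towards a lower number. Among the measured compounds shown here, no measured step tests this change directly, so the direction remains uncertain. The expected step is a 1.7-fold lower number from compound 2 to compound 3 (0.22 log units; within the scatter). For compound 3 the estimated value is 300 nM, with an expected range of 60 nM to 1500 nM.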

Compound 3, half-maximal inhibitory concentration: 600 nM
Beside the measured number, compound 3's estimate is 2.0-fold (0.30 log units) below it; the range from low to high includes it.
By their numbers in this assay, from the lowest: compounds 2 and 3 (each within the scatter of the next); then compound 1.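

In this assay, putting methylsulfonyl at this aromatic carbon in place of the group in compound 2 gives a 1.2-fold higher number from compound 2 to compound 3 (0.08 log units; within the scatter), which lies within the scatter, so the assay does not separate these two sulfur groups. Measured against the methyl group, methylsulfonyl gives a 67-fold lower number from compound 1 to compound 3 (1.82 log units; beyond the scatter), beyond the scatter, so the large gain seen earlier is not confined to the group in compound 2 but is shared by both sulfur groups. Nothing available explains why either sulfur group differs from methyl.

The compounds shown leave open whether sulfur is needed at this place at all, or whether a nitrile, an amide or a methylthio group would serve as well. As far as these compounds go, the cyclopentyl group and both chlorines stay the same throughout, so what each contributes also remains open.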